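Benzyl in place of phenyl on an aromatic nitrogen

A few compounds are considered here, and "the series" means these few. Any claim that something is new, unique, unknown or untested is made for them only; others in the source may bear on it.

Compound 1 `C/C=C/Cn1cc(/C=C/C(=O)CC(=O)C(=O)OCC)c2ccccc21` in an assay on isolated protein for inhibition of DNA nucleotidylexotransferase (Homo sapiens), read by scintillation counting, with a stated time of 10 min; a lower number here means a stronger inhibitor, a higher number a weaker inhibitor: > 40 uM, a limit of the assay.
Compound 2 `CCOC(=O)C(=O)CC(=O)/C=C/c1cn(C=C(C)C)c2ccccc12` in this assay: > 40 uM, a limit of the assay.
Compound 3 `CCOC(=O)C(=O)CC(=O)/C=C/c1cn(-c2ccccc2)c2ccccc12` in this assay: > 40 uM, a limit of the assay.

Compound 3 stands at a limit only in this assay, and the two further values shown are limits as well, so none of the three can be set above or below another. The three steps that join them, a step that the two limits leave unreadable from compound 1 to compound 2, a step that the two limits leave unreadable from compound 1 to compound 3 and a step that the two limits leave unreadable from compound 2 to compound 3, each have a size that the limits leave unreadable, and the one shared observation, (the limit of > 40 uM in this assay, at which 3 of the 3 values shown sit), records simply that all three values sit at the same limit.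

Compound 4 `CCOC(=O)C(=O)CC(=O)/C=C/c1cn(Cc2ccccc2)c2ccccc12` differs from compound 3 in one place: benzyl in place of phenyl on an aromatic nitrogen. Going by the values given here, the steps that bear on this change are those among compounds 1, 2 and 3, where three different groups on the same aromatic nitrogen all returned a limit, so their sizes cannot be read and no direction can be drawn from them. Compound 4 is therefore expected to behave like the others in this assay, with a step that the limit leaves unreadable from compound 3 to compound 4 expected to stay within the scatter and the result most likely reported again as a limit. The estimate for compound 4 in this assay is 60 uM, with a range from 20 uM to 200 uM.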

Compound 4, concentration for 50% inhibition: > 40 uM
Compound 4: only a limit was reported; the forecaster's own chance of this, stated with the estimate: 85%; the middle value lies beyond the limit too.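

In this assay compound 4 gives > 40 uM, a limit of the assay, so its steps from compound 1, compound 2 and compound 3 cannot be read. All four compounds end at the same point: the limit of > 40 uM in this assay, at which 4 of the 4 values shown sit. The compounds shown leave open whether any group on the aromatic nitrogen gives a measurable inhibition, and how large it would be.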